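From Compound 2 to Compound 3: Methoxy for Fluoro

The source may report more compounds than this note shows. Statements on the series, on what has been measured and on what is new or still open speak of the compounds shown alone.

Among the measured compounds shown here, compound 2, `CSc1ccc(F)cc1NCC1=NCCN1`, is the one member of this set with a number in an assay on CHO cells for binding affinity to Alpha-2B adrenergic receptor (Homo sapiens), read by radioligand binding (a higher number here means a weaker inhibitor, a lower number a stronger inhibitor), where compound 2 gives 331 nM. Compound 1, `CS(=O)(=O)c1cc(Cl)ccc1NCC1=NCCN1`, reaches only a limit of the assay: in this assay compound 1 gives < 6310 nM. Compound 3, `COc1ccc(SC)c(NCC2=NCCN2)c1`, has not yet been measured. It differs from compound 2 by methoxy in place of fluoro on an aromatic carbon. For the measured compounds named here, no measured pair shows this change, so the expected step of a 1.5-fold higher number from compound 2 to compound 3 (0.18 log units; within the scatter) is modest and not beyond the usual scatter. In this assay compound 3 is expected to give 500 nM, within 150 nM to 1800 nM.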

Compound 3, inhibition constant: < 6310 nM
Compound 3 gave a limit, no number; the forecaster's own chance of this, stated with the estimate: 10%; the middle value does not contradict the limit.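

In this assay, among the compounds shown here, compound 3 gives only a limit of < 6310 nM and so no step from compound 2 to compound 3 can be read. The compounds shown leave open what methoxy in place of fluoro does to the binding affinity.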